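Swapping the ring on the lactam nitrogen of compound 1

A few compounds are considered here, and "the series" means these few. Any claim that something is new, unique, unknown or untested is made for them only; others in the source may bear on it.

Compound 1 `COC(=O)c1nnn([C@@H]2C(=O)N(c3ccc(C)cc3)[C@@H]2/C=C/c2ccccc2)c1C(=O)OC` carries a 4-methylphenyl group on the amide-type nitrogen of its four-membered ring. In a functional assay on KB cells (Homo sapiens) for inhibition (on this read-out lower numbers stand for stronger inhibition and higher numbers for weaker inhibition), compound 1 stands as "not determined" (no result reported); no result was reported for it. Among the measured compounds shown here, the only value comes from a related compound, compound 2 `O=C1[C@@H](n2cc(-c3ccccc3)nn2)[C@@H](/C=C/c2ccccc2)N1c1ccccc1`, which has a different set of substituents; in this assay compound 2 gives 91300 nM, a weak inhibition. Compound 3 `COC(=O)c1nnn([C@@H]2C(=O)N(C3CCCCC3)[C@@H]2/C=C/c2ccccc2)c1C(=O)OC` is the next compound to be tested. It differs from compound 1 in one place: cyclohexyl in place of 4-methylphenyl on an amide-type nitrogen in a ring. For the measured compounds named here, with no measured step between compound 1 and compound 3, and no number for compound 1 at all, the expectation rests on the weak result of compound 2 alone. A shift of moderate size in either direction would not be surprising, and a result within the scatter of a weak value is the most likely outcome. Compound 3 is expected to give about 60000 nM in this assay, with an estimated range from 15000 nM to 200000 nM.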

Compound 3, half-maximal inhibitory concentration: > 228000 nM
Compound 3: no number, only a limit; the forecaster's own chance of this, stated with the estimate: 35%; middle value at least 3.8-fold (0.57 log units) away from the limit.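

In this assay compound 3 gives > 228000 nM, which is a limit and not a number. Among the compounds shown here, compound 1 has no reported result, so no step from compound 1 to compound 3 can be read. The compounds shown leave open how cyclohexyl and 4-methylphenyl on the amide-type nitrogen compare for inhibition on this shared core.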